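A Trifluoromethyl Swap Carried from One Core to Another

The source may hold more compounds than are shown below. What is called first, only, known or untested is meant among the compounds shown, and "the series" means these compounds.

Measured so far:
Compound 1 `COc1ccc2cc(-c3nn[nH]n3)cnc2c1` gives 5 mg/kg in a functional assay on the whole organism (strain Sprague-Dawley) for inhibition, with Rattus norvegicus as the target; a lower number here means that less compound is needed, a higher number that more compound is needed for the effect.
Compound 2 `COc1ccc2ncc(C(=O)O)cc2c1` gives only a limit in this assay, namely > 5 mg/kg.
Compound 3 `FC(F)(F)c1ccc2cc(-c3nn[nH]n3)cnc2c1` also gives only a limit in this assay, namely < 10 mg/kg.

Compound 1 and compound 3 share a core and differ in one place: trifluoromethyl in place of methoxy on an aromatic carbon. The step that the limit leaves unreadable from compound 1 to compound 3 cannot be sized because compound 3 sits at the limit of < 10 mg/kg in this assay, at which 1 of the 3 values shown sits. What can be said is that the two values do not contradict each other, so the change appears to be tolerated on that core.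

Compound 2 carries a different core, and how the two cores differ is not broken down here. Compound 2 stands at the limit of > 5 mg/kg in this assay, at which 1 of the 3 values shown sits, so its position is known only as a limit.

Compound 4 `O=C(O)c1cnc2ccc(C(F)(F)F)cc2c1` is not yet measured. It is related to compound 2 by the same change seen between compound 1 and compound 3: trifluoromethyl in place of methoxy on an aromatic carbon. The place of the change is the same on both cores.

On that basis the step from compound 2 to compound 4 is expected to be a step that the limit leaves unreadable from compound 2 to compound 4, and this expectation rests on compound 2 giving only a limit, > 5 mg/kg. Compound 4 is therefore estimated at 10 mg/kg, with an expected range from 4 mg/kg to 30 mg/kg, and a good chance that this assay again reports only a limit.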

Compound 4, minimum effective dose: > 25 mg/kg
Compound 4 gave a limit, no number; the forecaster's own chance of this, stated with the estimate: 60%; middle value at least 2.5-fold (0.39 log units) away from the limit.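

In this assay compound 4 gives > 25 mg/kg, which is a limit and not a number. Compound 2 also stands only at a limit, so no step can be read between compound 2 and compound 4. The compounds shown leave open whether trifluoromethyl in place of methoxy on an aromatic carbon changes the minimum effective dose on either core, and whether it does so alike on both.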